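A few compounds are considered here, and "the series" means these few. Any claim that something is new, unique, unknown or untested is made for them only; others in the source may bear on it.

Measured so far:
compound 1, `COc1ccc(-c2scc3c2CCOC32CCN(Cc3ccccc3)CC2)cc1`, 1.5 nM
compound 2, `COC1Cc2c(csc2-c2ccc(C)cc2)C2(CCN(Cc3ccccc3)CC2)O1`, 2 nM

In an assay on membranes from brain for displacement of a labelled ligand from Sigma non-opioid intracellular receptor 1 (Cavia porcellus), read by scintillation counting, with a stated time of 120 min (a higher number here means a weaker inhibitor, a lower number a stronger inhibitor), compound 2 gives 2 nM, the upper of the two numbers, though its gap to compound 1 lies within the scatter. Compound 3, `COc1ccc(-c2scc3c2CC(OC)OC32CCN(Cc3ccccc3)CC2)cc1`, is not yet measured. It differs from compound 2 by methoxy in place of methyl on an aromatic carbon. Compound 1 already carries a 4-methoxyphenyl and gives 1.5 nM in this assay, so no step beyond the scatter is expected here. The step from compound 2 to compound 3 is estimated at a 1.3-fold lower number from compound 2 to compound 3 (0.10 log units; within the scatter). Compound 3 is expected to give 1.6 nM, within a range from 0.6 nM to 4 nM.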

Compound 3, inhibition constant: 2.2 nM
Beside the measured number, compound 3's estimate is 1.4-fold (0.14 log units) below it; the range from low to high includes it.
By their numbers in this assay, from the lowest: compounds 1, 2 and 3 (each within the scatter of the next).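

In this assay, the exchange of 4-methylphenyl for 4-methoxyphenyl gives a 1.1-fold higher number from compound 2 to compound 3 (0.04 log units; within the scatter) and so leaves the number unmoved at this position on the ring. Methoxy on the saturated ring carbon gives a 1.5-fold higher number from compound 1 to compound 3 (0.17 log units; within the scatter) and is likewise tolerated, so both changes fit on this core without a step beyond the scatter. Nothing at hand explains this result. Still open, on these data alone, is whether an amine or a carboxylic acid on the aromatic ring would hold the number, and whether a longer chain on the saturated ring carbon would.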